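The source may hold more compounds than are shown below. What is called first, only, known or untested is meant among the compounds shown, and "the series" means these compounds.

In a functional assay on UACC-257 cells (Homo sapiens) for inhibition, read by sulforhodamine B assay, with a stated time of 48 h (on this read-out higher numbers stand for weaker inhibition of growth and lower numbers for stronger inhibition of growth), compound 1 `Cc1ccc(NC(=O)/C=C/c2ccccc2)c(C(N)=O)c1` gives 17000 nM and compound 3 `NC(=O)c1cc(I)ccc1NC(=O)/C=C/c1ccccc1` gives 14300 nM, so these two stand level within the scatter. Compound 2 `NC(=O)c1cc(Br)ccc1NC(=O)/C=C/c1ccccc1` stands as "not determined" (no result reported), with no result reported, which leaves only those two numbers in the series.

Compound 4 `NC(=O)c1cc(I)ccc1NC(=O)/C=C/c1ccccc1Cl` keeps the iodo group of compound 3 and carries one change, (chloro in place of hydrogen on an aromatic carbon), which turns phenyl into 2-chlorophenyl. Among the measured compounds shown here, the only measured step, a 1.2-fold lower number from compound 1 to compound 3 (0.08 log units; within the scatter), is iodo in place of methyl on an aromatic carbon. It stays within the scatter and concerns a different place in the structure. For the measured compounds named here, no measured pair varies the phenyl group, so the data give no direct guide to this change, and the wide range below reflects that. With the small step from compound 1 as the sole reference, no shift beyond the scatter is expected in this assay. The expected size is a 1.1-fold lower number from compound 3 to compound 4 (0.04 log units; within the scatter) and this remains a weakly supported estimate. Compound 4 is estimated at 13000 nM, with an expected range from 5000 nM to 30000 nM.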

Compound 4, concentration for 50% growth inhibition: 38700 nM
Compound 4: the middle estimate sits 3.0-fold (0.47 log units) below what was measured; the whole stated range lies below it.
By their numbers in this assay, from the lowest: compounds 3 and 1 (each within the scatter of the next); then compound 4.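

In this assay, among the compounds shown here, chloro in place of hydrogen on an aromatic carbon gives a 2.7-fold higher number from compound 3 to compound 4 (0.43 log units; beyond the scatter) and is the only step that lies beyond the scatter. The phenyl group is therefore not a silent place: with the iodo group held fixed, going to 2-chlorophenyl weakens inhibition of growth, whereas the earlier exchange of methyl for iodo left the numbers level. No measurement at hand accounts for this loss.

Going by these compounds, the finding rests on a single pair, so it remains open whether the loss is specific to chloro or extends to other groups at this place, such as fluoro, methyl or methoxy. On these data alone, it is also open whether the same loss appears when methyl replaces iodo on the core.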